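Replacing chloro with methyl on compound 3

This account rests on a few compounds, and the source may have more. Where it says the series, first, only, none or still open, it means among the compounds named here.

In a functional assay on MGC-803 cells (Homo sapiens) for antiproliferative activity, read by MTT assay, with a stated time of 72 h (a higher number here means a weaker inhibitor, a lower number a stronger inhibitor), compound 3 `O=C(NO)c1ccc(NCc2nc(-c3ccccc3)nn2-c2cccc(Cl)c2)cc1` gives 13700 nM and stands above compound 2 `O=C(NO)c1ccc(NCc2nc(-c3cccc(Cl)c3)nn2-c2ccccc2)cc1` at 5760 nM by a gap beyond the scatter. Compound 1 `Cc1ccc(-c2nc(CNc3ccc(C(=O)NO)cc3)n(-c3ccccc3)n2)cc1` reads > 20000 nM as a limit of the assay. Compound 4 `Cc1cccc(-n2nc(-c3ccccc3)nc2CNc2ccc(C(=O)NO)cc2)c1` carries methyl in place of chloro on an aromatic carbon, meta to a large group (methyl in place of chloro on an aromatic carbon). For the measured compounds named here, the one measured step of an at least 3.4-fold lower number from compound 1 to compound 2 (0.54 log units; beyond the scatter) puts 3-chlorophenyl in place of 4-methylphenyl on a different phenyl group, so it bears only loosely on this change. It points towards a higher number in this assay for the methyl compound, and the expected 1.4-fold higher number from compound 3 to compound 4 (0.14 log units; within the scatter) is small. Compound 4 is estimated at 19000 nM with a range from 9000 nM to 40000 nM in this expectation.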

Compound 4, half-maximal inhibitory concentration: 13200 nM
Compound 4: the middle estimate sits 1.4-fold (0.16 log units) above what was measured; measured number inside the range.
By their numbers in this assay, from the lowest: compound 2; then compounds 4 and 3 (each within the scatter of the next). At a limit, above all of these: compound 1.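

On this phenyl group, going from 3-chlorophenyl to 3-methylphenyl does not separate the two groups in this assay: a 1.0-fold lower number from compound 3 to compound 4 (0.02 log units; within the scatter). This is the first step shown at this position, as the earlier step concerned a different phenyl group, and here chloro and methyl cannot be told apart. Compound 1 alone stands at the limit of the assay, which caps the range that can be read: the limit of > 20000 nM in this assay, at which 1 of the 4 values shown sits.

As far as these compounds go, whether an amine or a carboxylic acid on the same carbon would depart from chloro and methyl stays open. So does whether chloro and methyl also match on the other phenyl group.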